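Swapping an Ester Arm: From Propargyl to Dinitrophenyl

The source may hold more compounds than are shown below. What is called first, only, known or untested is meant among the compounds shown, and "the series" means these compounds.

Two compounds sharing one core have been compared in a functional assay on HEK293 cells for antagonist activity at Voltage-dependent L-type calcium channel subunit alpha-1D (Rattus norvegicus), read by FLIPR; on this read-out lower numbers stand for stronger inhibition and higher numbers for weaker inhibition. Compound 1 `CCOC(=O)C1=C(C)NC(/C=C/c2ccc([N+](=O)[O-])cc2)=C(C(=O)OCC)C1c1cccc([N+](=O)[O-])c1` gives 2060 nM. Compound 2 `C#CCCOC(=O)C1=C(C)NC(C)=C(C(=O)OC)C1c1cccc([N+](=O)[O-])c1` gives 35 nM in this assay, the lowest of the two numbers shown, with compound 1 standing beyond the scatter above it. Compound 3 `COC(=O)C1=C(C)NC(C)=C(C(=O)OCc2cc([N+](=O)[O-])cc([N+](=O)[O-])c2)C1c1cccc([N+](=O)[O-])c1` has not yet been measured; it differs from compound 2 by 3,5-dinitrophenyl in place of propargyl on a saturated chain carbon bound to an oxygen next to a carbonyl group. Among the measured compounds shown here, no measured pair shows this change, so its effect cannot be read from what has been measured. Because compound 2 already gives 35 nM, a moderate loss of potency is expected rather than a gain, and the step from compound 2 to compound 3 is estimated at a 3.4-fold higher number from compound 2 to compound 3 (0.54 log units; beyond the scatter). Compound 3 is therefore expected to give about 120 nM, within a range from 25 nM to 600 nM.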

Compound 3, half-maximal inhibitory concentration: 40 nM
Compound 3: middle estimate off by 3.0-fold (0.48 log units), on the high side, and the stated range covers the measured number.
By their numbers in this assay, from the lowest: compounds 2 and 3 (each within the scatter of the next); then compound 1.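

In this assay, putting 3,5-dinitrophenyl in place of propargyl on a saturated chain carbon bound to an oxygen next to a carbonyl group gives a 1.1-fold higher number from compound 2 to compound 3 (0.06 log units; within the scatter). Among the compounds shown here, this is the first measured step at this position, and it shows that a group of 12 heavy atoms with an aromatic ring can stand in for one of 3 heavy atoms with a triple bond, with no change beyond the scatter. No evidence at hand bears on why the two groups read alike.

Going by these compounds, with only these two groups compared at this position, how far the tolerance extends stays open. Whether an amine, a carboxylic acid or a longer chain of saturated carbons would read the same in this assay cannot be told from the compounds shown.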